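The source may report more compounds than this note shows. Statements on the series, on what has been measured and on what is new or still open speak of the compounds shown alone.

In a functional assay on NCI-H23 cells (Homo sapiens) for inhibition, read by sulforhodamine B assay, with a stated time of 48 h (a lower number here means that less compound is tolerated, a higher number that more compound is tolerated), compound 1, `COc1ccc(-c2cc(/C=C/C(=O)c3ccc(N)cc3)[nH]n2)cc1`, gives 68400 nM. Compound 3, `COc1ccc(-c2cc(/C=C/C(=O)c3ccc(N)cc3)[nH]n2)cc1OC`, carries one further group on the shared core, and in this assay compound 3 gives 95600 nM. The change between the two is methoxy in place of hydrogen on an aromatic carbon and it made a 1.4-fold higher number from compound 1 to compound 3 (0.15 log units; within the scatter).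

Compound 2, `COc1ccc(C(=O)/C=C/c2cc(-c3cc(OC)c(OC)c(OC)c3)n[nH]2)cc1OC`, rests on a different core, and the difference between the two cores is not broken down here. In this assay compound 2 gives 22700 nM, the lowest of the three numbers, with gaps to compound 1 and to compound 3 that both lie beyond the scatter.

Compound 4, `COc1cc(C(=O)/C=C/c2cc(-c3cc(OC)c(OC)c(OC)c3)n[nH]2)cc(OC)c1OC`, has not yet been measured. It differs from compound 2 by methoxy in place of hydrogen on an aromatic carbon. Among the compounds with values here, this is the same kind of change as the one from compound 1 to compound 3, though not the same: in compound 4 the entering methoxy also stands meta to a methoxy group, whereas in compound 3 its place is ortho to a methoxy group and meta to a large group. Within the data shown here, the one earlier step of this kind, from compound 1 to compound 3, stayed within the scatter, and on that single precedent the account expects the step of a 1.3-fold higher number from compound 2 to compound 4 (0.12 log units; within the scatter), again a step within the scatter. Compound 4 is therefore estimated to give 30000 nM in this assay, with a likely range from 15000 nM to 60000 nM.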

Compound 4, concentration lethal to 50% of the cells: 64300 nM
Beside the measured number, compound 4's estimate is 2.1-fold (0.33 log units) below it; measured number above the stated range.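

In this assay, methoxy in place of hydrogen on an aromatic carbon gave a 2.8-fold higher number from compound 2 to compound 4 (0.45 log units; beyond the scatter), a step that on this core stands clear of the usual scatter. Set beside the earlier step on the other core, it gives no sign that the change behaves differently from one core to the other, since the gap between the two steps stays within what two such steps can scatter: the same change on two cores in this assay, a 1.4-fold higher number (0.15 log units; within the scatter) from compound 1 to compound 3 and a 2.8-fold higher number (0.45 log units; beyond the scatter) from compound 2 to compound 4, 2.0-fold (0.31 log units) apart, within the scatter of two such steps This does not show that the step has the same size on both cores, for one step lies within the scatter and the other beyond it, only two pairs are available, and the entering methoxy stands meta to a methoxy group in compound 4 but meta to a large group in compound 3, so any carrying over rests on thin ground.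

The compounds shown leave open whether the step would hold on a third core, or at other places on the same aromatic ring. They also leave open whether a hydroxy group or a longer chain such as ethoxy, entering at the same aromatic carbon, would give a step like that of methoxy.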